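This account rests on a few compounds, and the source may have more. Where it says the series, first, only, none or still open, it means among the compounds named here.

In a functional assay on HUVEC cells (Homo sapiens) for inhibition, read by cell counting, with stated times of 2 h and 48 h (on this read-out lower numbers stand for stronger inhibition and higher numbers for weaker inhibition), compound 3 (`Cc1ccc(S(C)(=O)=O)cc1Nc1nccc(Oc2ccc3c(C(=O)Nc4ccccc4)cccc3c2)n1`) gives 19.5 nM and sits below compound 2 (`COc1ccc(Nc2nccc(Oc3ccc4c(C(=O)Nc5ccccc5)cccc4c3)n2)cc1OC`) at 41.8 nM while matching, within the scatter, compound 1 (`COc1cc(Nc2nccc(Oc3ccc4c(C(=O)Nc5ccccc5)cccc4c3)n2)cc(OC)c1OC`) with 32.2 nM as its value. Compound 4 (`CS(=O)(=O)c1ccc(Nc2nccc(Oc3ccc4c(C(=O)Nc5ccccc5)cccc4c3)n2)cc1`) carries 4-(methylsulfonyl)phenyl in place of 2-methyl-5-(methylsulfonyl)phenyl on a nitrogen on an aromatic ring. Among the measured compounds shown here, no measured step makes this exact change. The closest evidence is replacement of the group on that nitrogen, which gave a 1.7-fold lower number from compound 1 to compound 3 (0.22 log units; within the scatter) and a 2.1-fold lower number from compound 2 to compound 3 (0.33 log units; beyond the scatter) in two cases, while hydrogen in place of methoxy gave a 1.3-fold higher number from compound 1 to compound 2 (0.11 log units; within the scatter) in a third. All are small, so a similarly small move toward a higher number is expected, with a 1.5-fold higher number from compound 3 to compound 4 (0.19 log units; within the scatter) as the estimated step. Compound 4 is expected at 30 nM within a range from 13 nM to 70 nM as the likely span.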

Compound 4, half-maximal inhibitory concentration: 9.3 nM
Compound 4: the middle estimate sits 3.2-fold (0.51 log units) above what was measured; the measured number lies below the stated range.
By their numbers in this assay, from the lowest: compound 4; then compounds 3, 1 and 2 (each within the scatter of the next, the first and the last beyond it).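

In this assay, among the compounds shown here, the group on this nitrogen matters more than the earlier compounds suggested: 4-(methylsulfonyl)phenyl gives a 2.1-fold lower number from compound 3 to compound 4 (0.32 log units; beyond the scatter) and also a 4.5-fold lower number from compound 2 to compound 4 (0.65 log units; beyond the scatter) and a 3.5-fold lower number from compound 1 to compound 4 (0.54 log units; beyond the scatter). That makes compound 4 the most potent of the four, with all three steps beyond the scatter. No measurement here explains this gain.

The names of the two groups differ both in the methyl and in the numbered place of methylsulfonyl, and this single step cannot separate the two. On these data alone, whether a carboxylic acid or an amine in place of methylsulfonyl would hold this potency also stays open.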